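The source may hold more compounds than are shown below. What is called first, only, known or untested is meant among the compounds shown, and "the series" means these compounds.

Measured compounds
Compound 1 `Cc1c(-c2ccc(Cc3ccc(C(O)C(F)(F)F)cc3)cc2)[nH]c2cccc(F)c2c1=O` gives > 10000 nM in an ADME assay on Huh7.5.1 cells (Homo sapiens) for cytotoxicity, read by WST assay, with a stated time of 48 h; a higher number here means that more compound is tolerated, a lower number that less compound is tolerated.
Compound 2 `Cc1c(-c2ccc(Cc3ccc(OC(F)F)cc3)cc2)[nH]c2cccc(F)c2c1=O` gives > 5000 nM in this assay.

Both of these values are limits of this assay rather than numbers. Compound 1 sits at the limit of the limit of > 10000 nM in this assay, at which 1 of the 2 values shown sits, and that is all that is known of where it stands. Compound 2 sits at the limit of the limit of > 5000 nM in this assay, at which 1 of the 2 values shown sits. The step that the two limits leave unreadable from compound 1 to compound 2 is therefore unreadable: the change of difluoromethoxy in place of 2,2,2-trifluoro-1-hydroxyethyl on an aromatic carbon leaves no measurable mark.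

Compound 3 `Cc1c(-c2ccc(Cc3ccc(Cl)cc3)cc2)[nH]c2cccc(F)c2c1=O` carries the change (chloro in place of 2,2,2-trifluoro-1-hydroxyethyl on an aromatic carbon). For the measured compounds named here, the only measured step that bears on it, the one from compound 1 to compound 2, was itself hidden by two limits, so its size offers no guide. With both known values at the ceiling of this assay, compound 3 is expected to stay at or near that ceiling, with the step of a number no higher from compound 1 to compound 3 (the limit leaves the size open) expected to lie within the scatter. Compound 3 is estimated at 10000 nM, in the range 3000 nM to 30000 nM.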

Compound 3, half-maximal cytotoxic concentration: > 10000 nM
Compound 3 ended at the assay's limit (the forecaster's own chance of this, stated with the estimate: 70%); the middle value lies on the limit itself.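

In this assay compound 3 gives > 10000 nM, which is a limit and not a number. The steps among compound 1, compound 2 and compound 3 therefore cannot be read. The compounds shown leave open where each true cytotoxic concentration lies and whether these group changes alter it.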